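A few compounds are considered here, and "the series" means these few. Any claim that something is new, unique, unknown or untested is made for them only; others in the source may bear on it.

In a functional assay on M21 cells (Homo sapiens) for antiproliferative activity, read by sulforhodamine B assay, with a stated time of 48 h (a lower number here means a stronger inhibitor, a higher number a weaker inhibitor), the three measured compounds stand as follows.

Compound 1 `CCc1ccccc1NS(=O)(=O)c1ccc(N2CCNC2=O)cc1`: 180 nM
Compound 2 `Cc1cccc(NS(=O)(=O)c2ccc(N3CCNC3=O)cc2)c1`: 69 nM
Compound 3 `O=C1NCCN1c1ccc(S(=O)(=O)Nc2ccc(Br)cc2)cc1`: 130 nM

Compound 1 has the highest number of the three. Its gap to compound 3 is small, a 1.4-fold lower number from compound 1 to compound 3 (0.14 log units; within the scatter), which is within the usual scatter, so those two cannot be told apart. Its gap to compound 2 is larger, a 2.6-fold lower number from compound 1 to compound 2 (0.42 log units; beyond the scatter), which is beyond the scatter and counts as a real, if modest, gain. Compound 2 and compound 3 differ by a 1.9-fold higher number from compound 2 to compound 3 (0.28 log units; within the scatter), again within the scatter.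

Compound 4 `COc1cccc(NS(=O)(=O)c2ccc(N3CCNC3=O)cc2)c1` is not yet measured. It differs from compound 1 in one place: 3-methoxyphenyl in place of 2-ethylphenyl on a sulfonamide nitrogen. All three measured compounds share the same core and differ only in the ring on the sulfonamide nitrogen, so every measured step bears on this change. The closest guide is the step to compound 2, where a 3-methylphenyl also replaced the 2-ethylphenyl; the 3-methoxyphenyl of compound 4 carries its group on the same ring with one oxygen in place of a carbon. The expectation is therefore a lower number for compound 4, of about the size seen for compound 2, and compound 4 is estimated at 80 nM, between 35 nM and 200 nM. That estimated step, a 2.3-fold lower number from compound 1 to compound 4 (0.35 log units; beyond the scatter), is expected to lie beyond the scatter.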

Compound 4, half-maximal inhibitory concentration: 65 nM
The estimate for compound 4 lay 1.2-fold (0.09 log units) above the measured number; measured number inside the range.
By their numbers in this assay, from the lowest: compounds 4, 2, 3 and 1 (each within the scatter of the next, the first and the last beyond it).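

In this assay, the 3-methoxyphenyl group on the sulfonamide nitrogen gives a step from the 2-ethylphenyl of compound 1 (a 2.8-fold lower number from compound 1 to compound 4 (0.44 log units; beyond the scatter)), which makes it the second ring to clear the scatter against compound 1, yet putting methoxy in place of methyl on the aromatic carbon makes no difference that can be read (a 1.1-fold lower number from compound 2 to compound 4 (0.03 log units; within the scatter)). At this position, then, an oxygen in the substituent can be present or absent without any visible effect on the number, a point that compounds 1, 2 and 3 could not address. The 4-bromophenyl ring of compound 3 also cannot be separated from the new ring (a 2.0-fold lower number from compound 3 to compound 4 (0.30 log units; within the scatter)), so compounds 2, 3 and 4 form one group with no internal order, and only compounds 2 and 4 stand clearly apart from compound 1. Nothing shown here gives a reason for any of these steps.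

Compound 1 differs from the others in both the group and its place on the ring, so the two effects remain tangled, and a 3-ethylphenyl ring would be needed to pull them apart. As far as these compounds go, it also remains open whether this position would tolerate a very different group, such as an amine, a carboxylic acid or a longer chain.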